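The compounds below may be only part of what the source reports. "The series", "measured", "known", "first", "only" and "open" are said of these compounds alone.

Measured so far in a functional assay on K562 cells (Homo sapiens) for antiproliferative activity, read by MTT assay, with a stated time of 72 h; on this read-out higher numbers stand for weaker inhibition and lower numbers for stronger inhibition:
- compound 1 `COc1cc(-c2ncnn2-c2ccc(Cl)cc2Cl)cc(OC)c1OC`: > 10000 nM, a limit
- compound 2 `COc1cc(-c2ncnn2-c2ccc(N)cc2)cc(OC)c1OC`: > 10000 nM, a limit

Compound 2 gives no number, and both compounds rest on (the limit of > 10000 nM in this assay, at which 2 of the 2 values shown sit). Compound 3 `COc1ccc(-n2ncnc2-c2cc(OC)c(OC)c(OC)c2)cc1` differs from compound 2 by methoxy in place of amino on an aromatic carbon, with 4-methoxyphenyl replacing 4-aminophenyl. For the measured compounds named here, the only measured step, a step that the two limits leave unreadable from compound 1 to compound 2, has no readable size and offers no magnitude to carry over. Any measurable value in this assay would lie toward stronger inhibition, though another limit remains quite possible. The expected change is an at least 3.3-fold lower number from compound 2 to compound 3 (0.52 log units; beyond the scatter), a tentative estimate. For compound 3 the estimated value is 3000 nM, with an expected range of 100 nM to 15000 nM.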

Compound 3, half-maximal inhibitory concentration: 3600 nM
For compound 3 the middle estimate is 1.2-fold (0.08 log units) below the measured one, and the stated range covers the measured number.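

In this assay, the group on this aromatic carbon, para to a large group, can move the series off its limit: methoxy in place of amino gives an at least 2.7-fold lower number from compound 2 to compound 3 (0.44 log units; beyond the scatter). 4-Methoxyphenyl in place of 2,4-dichlorophenyl on the aromatic nitrogen likewise gives an at least 2.7-fold lower number from compound 1 to compound 3 (0.44 log units; beyond the scatter). Both sizes are minimums, and the step between the two limit compounds cannot be read: the limit of > 10000 nM in this assay, at which 2 of the 3 values shown sit.

Still open, from the compounds shown here alone, is which part of methoxy carries the change. Hydroxy, ethoxy or methyl on the same carbon would separate the oxygen from the methyl.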